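This account rests on a few compounds, and the source may have more. Where it says the series, first, only, none or still open, it means among the compounds named here.

Measured in a functional assay on BGC-823 cells (Homo sapiens) for antiproliferative activity, read by MTT assay, with a stated time of 72 h; on this read-out higher numbers stand for weaker inhibition and lower numbers for stronger inhibition:

compound 1 `O=C(Nc1ccccc1)C(Cl)Cl`: "not determined" (no result reported)
compound 2 `O=C(Nc1cccc(I)c1)C(Cl)Cl`: 58800 nM
compound 3 `N#Cc1cccc(NC(=O)C(Cl)Cl)c1`: "not determined" (no result reported)

Compound 3 stands without a number in this assay, and compound 1 is a second entry without a number, so only compound 2 gives a value on this read-out. Compound 4 `O=C(Nc1cccc(OC(F)(F)F)c1)C(Cl)Cl` differs from compound 3 in one place: trifluoromethoxy in place of cyano on an aromatic carbon. For the measured compounds named here, no step between two measured compounds is available to set the size or direction of this change, and compound 3 itself offers no starting value. The only anchor is the weak inhibition shown by compound 2. On that basis compound 4 is expected to be a weak inhibitor as well, estimated at 50000 nM with a range from 8000 nM to 200000 nM.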

Compound 4, half-maximal inhibitory concentration: 142000 nM
Compound 4: the middle estimate sits 2.8-fold (0.45 log units) below what was measured; measured number inside the range.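

In this assay, for the compounds shown here, placing trifluoromethoxy where iodo sat gives a 2.4-fold higher number from compound 2 to compound 4 (0.38 log units; beyond the scatter), the first readable step at this position, and it shows that the choice of group here changes the result modestly, with weaker inhibition for trifluoromethoxy. Nothing available explains this difference. Steps involving compound 1 or compound 3 cannot be read, as neither has a number.

So the effect of adding any group to the unsubstituted compound 1 remains open, as does how a group such as an amine or a carboxylic acid would fare at this position.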